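A few compounds are considered here, and "the series" means these few. Any claim that something is new, unique, unknown or untested is made for them only; others in the source may bear on it.

Compound 1 `CCOC(=O)c1c(-c2cccc(OC)c2)[nH]c2cc(F)cc(F)c2c1=O` and compound 2 `CCOC(=O)c1c(-c2cccc(Oc3ccccc3)c2)[nH]c2cc(F)cc(F)c2c1=O` share one core, while compound 3 `CCOC(=O)c1c(-c2cccc(OC)c2)[nH]c2cc(Cl)c(Cl)cc2c1=O` is built on a second core; the difference between the two cores is not broken down here. In an ADME assay on HEK293 cells (Homo sapiens) for cytotoxicity, read by luminescence, with a stated time of 72 h (on this read-out lower numbers stand for an effect already at smaller amounts and higher numbers for an effect only at larger amounts of compound), compound 1 gives only a limit of the assay, namely > 22000 nM. In this assay compound 2 likewise gives only a limit, > 22000 nM. In this assay compound 3 also gives only a limit, > 22000 nM. The change from compound 1 to compound 2 is phenyl in place of methyl on an oxygen on an aromatic ring, and its outcome is a step that the two limits leave unreadable from compound 1 to compound 2 because of the limit of > 22000 nM in this assay, at which 3 of the 3 values shown sit.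

Compound 4 `CCOC(=O)c1c(-c2cccc(Oc3ccccc3)c2)[nH]c2cc(Cl)c(Cl)cc2c1=O` has not yet been measured. It arises from compound 3 by the same change, (phenyl in place of methyl on an oxygen on an aromatic ring), at the same place. Since the earlier pair gives no readable step, an estimated step that the limit leaves unreadable from compound 3 to compound 4 in this assay is expected, because of the limit of > 22000 nM in this assay, at which 3 of the 3 values shown sit. On that basis compound 4 is expected to give about 30000 nM, most likely reported once more as a limit rather than a number, within an expected range from 15000 nM to 80000 nM.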

Compound 4, half-maximal effective concentration: > 22000 nM
Compound 4: a limit, no number (the forecaster's own chance of this, stated with the estimate: 85%); the middle value does not contradict the limit.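

In this assay compound 4 gives > 22000 nM as a limit and not a number. No size can be read for the change from methoxy to phenoxy between compound 3 and compound 4, because both compounds give only a limit: the limit of > 22000 nM in this assay, at which 4 of the 4 values shown sit. The compounds shown leave open at what concentration, if any, each would harm these cells.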